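Naphthalene for methoxyphenyl on a weak cytotoxic core

The source may report more compounds than this note shows. Statements on the series, on what has been measured and on what is new or still open speak of the compounds shown alone.

Measured compounds:
compound 1, `COc1ccc(C2=NN(C3=NC(=O)/C(=C4\C(=O)Nc5ccc(Br)cc54)S3)C(c3ccc(OC)cc3)C2)cc1`, 200 nM
compound 2, `COc1ccc(C2CC(c3ccc4ccccc4c3)=NN2C2=NC(=O)/C(=C3\C(=O)Nc4ccc(Br)cc43)S2)cc1`, 54 nM
compound 3, `COc1ccc(C2=NN(C3=NC(=O)/C(=C4\C(=O)Nc5ccccc54)S3)C(c3ccc(Cl)cc3)C2)cc1`, 92400 nM

The three measured compounds were tested in a functional assay on cells (Cancer cell lines, Homo sapiens) for cytotoxicity, read by sulforhodamine B assay, with a stated time of 48 h; a higher number here means a weaker inhibitor of growth, a lower number a stronger inhibitor of growth. Compound 1 gives 200 nM, and compound 2 gives 54 nM. The change between them is naphthalen-2-yl in place of 4-methoxyphenyl on a carbon with a double bond to nitrogen, and it made a 3.7-fold lower number from compound 1 to compound 2 (0.57 log units; beyond the scatter). Compound 3 sits far from both: in this assay compound 3 gives 92400 nM, the highest of the three numbers. The difference between the core of compound 3 and the core of compound 1 is not broken down here.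

Compound 4, `O=C1N=C(N2N=C(c3ccc4ccccc4c3)CC2c2ccc(Cl)cc2)S/C1=C1/C(=O)Nc2ccccc21`, has not yet been measured. It differs from compound 3 by naphthalen-2-yl in place of 4-methoxyphenyl on a carbon with a double bond to nitrogen. For the measured compounds named here, this is the same kind of change as the one from compound 1 to compound 2, though the surroundings are not identical: in compound 3 the ring atom two ring bonds away bears a 4-chlorophenyl group, whereas in compound 1 it bears a 4-methoxyphenyl group. Going by the values given here, only one earlier example of the change exists, and it occurs on a core whose difference from compound 3 is not counted here, so the transfer is uncertain. Because a 3.7-fold lower number from compound 1 to compound 2 (0.57 log units; beyond the scatter) lowered the number, compound 4 is expected to show a 3.7-fold lower number from compound 3 to compound 4 (0.57 log units; beyond the scatter). The estimate for compound 4 in this assay is 25000 nM, with a range from 5000 nM to 100000 nM.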

Compound 4, concentration for 50% growth inhibition: 460 nM
Compound 4: middle estimate off by 54-fold (1.74 log units), on the high side; measured number below the stated range.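

In this assay the new step is a 200-fold lower number from compound 3 to compound 4 (2.30 log units; beyond the scatter) and it runs the same way as the earlier one, so naphthalen-2-yl in place of 4-methoxyphenyl lowered the number on both cores shown. The size of the step, however, did not carry over from one core to the other: the same change on two cores in this assay, a 3.7-fold lower number (0.57 log units; beyond the scatter) from compound 1 to compound 2 and a 200-fold lower number (2.30 log units; beyond the scatter) from compound 3 to compound 4, 54-fold (1.73 log units) apart, beyond the scatter of two such steps

This shows that the direction of the change held on these two cores, and that the size measured on one core was a poor guide to the size on the other. It does not show why the two steps differ, and two cores are too few to establish a rule for the series, given that the core of compound 1 carries a bromine and a 4-methoxyphenyl group while the core of compound 3 has no bromine and a 4-chlorophenyl group.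

The compounds shown leave open whether the bromine, the 4-chlorophenyl group or the two together set the size of the step. They also leave open how the series would respond to other groups at the same carbon, such as a pyridine ring, an amine or a longer alkyl chain.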